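A few compounds are considered here, and "the series" means these few. Any claim that something is new, unique, unknown or untested is made for them only; others in the source may bear on it.

Compound 2 `COc1cccc([C@@H]2C[C@@H]3Cc4ccc5ccccc5c4N2O3)c1` is one of two close relatives tested in an ADME assay on THP-1 cells (Homo sapiens) for cytotoxicity, read by MTT assay, with a stated time of 72 h; a lower number here means that less compound is tolerated, a higher number that more compound is tolerated. In this assay compound 2 reaches only a limit of the assay, > 300000 nM. Compound 1 `Brc1ccc([C@@H]2C[C@@H]3Cc4ccc5ccccc5c4N2O3)cc1` carries 4-bromophenyl where compound 2 carries 3-methoxyphenyl. In this assay compound 1 likewise stops at a limit, > 250000 nM. The step from compound 1 to compound 2 is therefore a step that the two limits leave unreadable from compound 1 to compound 2; the two limits, the limit of > 250000 nM in this assay, at which 1 of the 2 values shown sits, and (the limit of > 300000 nM in this assay, at which 1 of the 2 values shown sits), leave its size and direction unknown.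

Compound 3 `Cc1cccc([C@@H]2C[C@@H]3Cc4ccc5ccccc5c4N2O3)c1` differs from compound 2 by methyl in place of methoxy on an aromatic carbon. For the measured compounds named here, no measured step bears directly on this change, and the one step that exists, a step that the two limits leave unreadable from compound 1 to compound 2, is itself unreadable. Both relatives show no measurable cytotoxicity within the tested range, so compound 3 is expected to behave the same way. The expected step is a number no higher from compound 2 to compound 3 (the limit leaves the size open), meaning no change beyond the scatter. The estimate for compound 3 in this assay is 300000 nM, within 150000 nM to 600000 nM, and most likely it will again be reported only as a limit.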

Compound 3, half-maximal cytotoxic concentration: > 300000 nM
Compound 3 gave a limit, no number; the forecaster's own chance of this, stated with the estimate: 90%; the middle value sits exactly at the limit.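

For the compounds shown here, compound 1, compound 2 and compound 3 all stop at limits in this assay, so no step among them can be read, in size or in direction. The compounds shown leave open the concentration at which any of them would harm these cells, and whether swapping the group on the shared core changes that concentration at all.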